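Fluorophenyl Amide Where Three Relatives Already Sit at the Ceiling

This account rests on a few compounds, and the source may have more. Where it says the series, first, only, none or still open, it means among the compounds named here.

Compound 3 `COc1cc(OC)cc(C(=O)NCCNC(=O)[C@H](CC(=O)NC(C)(C)C)NS(=O)(=O)c2ccc(C)cc2)c1` belongs to a small set of sulfonamide-derived amides sharing one core. In an ADME assay on HepG2 cells (Homo sapiens) for cytotoxicity (a lower number here means that less compound is needed, a higher number that more compound is needed for the effect), compound 3 gives > 11000 nM, which is a limit of the assay and not a number. Its two relatives stand the same way. Compound 1 `Cc1ccc(S(=O)(=O)N[C@@H](CC(=O)NC(C)(C)C)C(=O)NCCNC(=O)NCc2ccccc2)cc1` gives > 11000 nM in this assay, again a limit. Compound 2 `Cc1ccc(S(=O)(=O)N[C@@H](CC(=O)NC(C)(C)C)C(=O)NCCNC(=O)c2cc(Cl)ccc2Cl)cc1` gives > 11000 nM in this assay, once more a limit. Because all three values sit at the limit of > 11000 nM in this assay, at which 3 of the 3 values shown sit, none of the steps among them can be read: a step that the two limits leave unreadable from compound 1 to compound 3 and a step that the two limits leave unreadable from compound 2 to compound 3 remain unreadable, as does a step that the two limits leave unreadable from compound 1 to compound 2.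

Compound 4 `Cc1ccc(S(=O)(=O)N[C@@H](CC(=O)NC(C)(C)C)C(=O)NCCNC(=O)c2cccc(F)c2)cc1` differs from compound 3 in one place: 3-fluorophenyl in place of 3,5-dimethoxyphenyl on a carbonyl carbon. Within the data shown here, no measured step bears on this change with a readable size, since each lies between two limits, so no direction beyond the scatter can be expected. Compound 4 is therefore expected to give about 20000 nM in this assay, between 11000 nM and 50000 nM. That expectation means an estimated step that the limit leaves unreadable from compound 3 to compound 4.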

Compound 4, half-maximal effective concentration: > 11000 nM
Compound 4: a limit, no number (the forecaster's own chance of this, stated with the estimate: 85%); the middle value does not contradict the limit.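

Compound 4 also ends at a limit, so its steps from compound 1, compound 2 and compound 3 cannot be read, and no size can be given for any of them: the limit of > 11000 nM in this assay, at which 4 of the 4 values shown sit.

The compounds shown leave open whether any change on the carbonyl carbon alters the result in this assay.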